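Carbamate ester variants on the shared core: compound 4 outlook

The source may hold more compounds than are shown below. What is called first, only, known or untested is meant among the compounds shown, and "the series" means these compounds.

In an ADME assay on a cell-free system (plasma, Homo sapiens), read by HPLC, with a stated time of 120 min, at 37 degrees C (on this read-out higher numbers stand for a more stable compound and lower numbers for a less stable compound), compound 1 `CC(C)C(=O)OCOC(=O)N1CCN(C(=O)c2nc(Nc3cc(C4CC4)[nH]n3)c3cc(Cl)ccc3n2)C[C@H]1C` gives 6.1%, compound 2 `COC(=O)N1CCN(C(=O)c2nc(Nc3cc(C4CC4)[nH]n3)c3cc(Cl)ccc3n2)C[C@H]1C` gives 84.6% and compound 3 `C[C@@H]1CN(C(=O)c2nc(Nc3cc(C4CC4)[nH]n3)c3cc(Cl)ccc3n2)CCN1C(=O)OCC(Cl)(Cl)Cl` gives 79%. Compound 3 stands second highest of the three: its value and that of compound 2 lie within the scatter of each other, while it sits far above compound 1, as a number 72.9 percentage points higher from compound 1 to compound 3 (beyond the scatter) shows. Compound 4 `C[C@@H]1CN(C(=O)c2nc(Nc3cc(C4CC4)[nH]n3)c3cc(Cl)ccc3n2)CCN1C(=O)OCOC(=O)C(C)(C)C` differs from compound 3 by ((tert-butyl)carbonyl)oxy in place of trichloromethyl on a saturated chain carbon bound to an oxygen next to a carbonyl group. This runs the step of a number 72.9 percentage points higher from compound 1 to compound 3 (beyond the scatter) in reverse, with ((tert-butyl)carbonyl)oxy instead of (isopropylcarbonyl)oxy entering; a number 78.5 percentage points higher from compound 1 to compound 2 (beyond the scatter) points the same way. A large fall in this assay is therefore expected, a number 67 percentage points lower from compound 3 to compound 4 (beyond the scatter). Compound 4 is estimated at 12%, within 3% to 40%.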

Compound 4, percent of the compound remaining in the Homo sapiens assay: 0%
Estimate against measurement, compound 4: 12 percentage points above; the measured number lies below the stated range.
By their numbers in the Homo sapiens assay, from the lowest: compounds 4 and 1 (each within the scatter of the next); then compounds 3 and 2 (each within the scatter of the next).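

In the Homo sapiens assay compound 4 gives 0% and ((tert-butyl)carbonyl)oxy on a saturated chain carbon bound to an oxygen next to a carbonyl group gives a large fall against trichloromethyl (a number 79 percentage points lower from compound 3 to compound 4 (beyond the scatter)) and against hydrogen (a number 84.6 percentage points lower from compound 2 to compound 4 (beyond the scatter)). It is not told apart from (isopropylcarbonyl)oxy (a number 6.1 percentage points lower from compound 1 to compound 4 (within the scatter)). In a physicochemical assay, read by HPLC, in phosphate buffer, with a stated time of 2 h, at pH 7.4 (on this read-out higher numbers stand for a more stable compound and lower numbers for a less stable compound), compound 3 gives 98.7% and compound 4 gives 97.7% and the change from trichloromethyl to ((tert-butyl)carbonyl)oxy shows no such fall (a number 1 percentage points lower from compound 3 to compound 4 (within the scatter)).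

Open, on these data alone, is how an amine or a longer chain at this place would read in both assays. No measured evidence bears on why the two assays part.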